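From 1-aminocyclopropyl to 1-aminocyclopentyl on a carbonyl carbon

The source may hold more compounds than are shown below. What is called first, only, known or untested is meant among the compounds shown, and "the series" means these compounds.

Values so far in an in vitro ADME assay on microsomes (Rattus norvegicus) for metabolic stability; a higher number here means that the compound lasts longer, a lower number that the compound disappears faster (both are limits):
- compound 1 (`Cc1c2c(n3c1CCN(C(=O)C(C)(C)N)C[C@@H](C)[C@H](C)Nc1cc-3ccc1C(N)=O)CC(C)(C)CC2=O`) gives > 0.5 h as a limit
- compound 2 (`Cc1c2c(n3c1CCN(C(=O)C1(N)CC1)C[C@@H](C)[C@H](C)Nc1cc-3ccc1C(N)=O)CC(C)(C)CC2=O`) gives > 0.5 h as a limit

Compound 2 stands at > 0.5 h as a limit of the assay and not as a number. Compound 1 shares that limit, so both measured values sit together there (the limit of > 0.5 h in this assay, at which 2 of the 2 values shown sit).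

In compound 3 (`Cc1c2c(n3c1CCN(C(=O)C1(N)CCCC1)C[C@@H](C)[C@H](C)Nc1cc-3ccc1C(N)=O)CC(C)(C)CC2=O`) 1-aminocyclopentyl stands in place of 1-aminocyclopropyl on a carbonyl carbon (1-aminocyclopentyl in place of 1-aminocyclopropyl on a carbonyl carbon). Among the compounds with values here, the only measured step that bears on this is a step that the two limits leave unreadable from compound 1 to compound 2 in which 1-aminocyclopropyl replaces 1-amino-1-methylethyl on a carbonyl carbon. That step offers neither a size nor a direction. In this assay no step beyond the scatter is therefore expected, and no direction is assumed. Compound 3 may well report a limit too. The step expected is a step that the limit leaves unreadable from compound 2 to compound 3 as a rough estimate. For compound 3 the estimated half-life is 0.6 h (expected range 0.25 h to 1.6 h).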

Compound 3, half-life: 0.0833 h
Compound 3: the middle estimate sits 7.2-fold (0.86 log units) above what was measured, and the stated range ends above it.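

In this assay, the group on a carbonyl carbon now makes a readable difference: 1-aminocyclopentyl in place of 1-aminocyclopropyl gives an at least 6.0-fold lower number from compound 2 to compound 3 (0.77 log units; beyond the scatter), and 1-aminocyclopentyl in place of 1-amino-1-methylethyl gives an at least 6.0-fold lower number from compound 1 to compound 3 (0.77 log units; beyond the scatter). Both sizes are minimum sizes, and the step between the other two groups cannot be read, so nothing orders 1-amino-1-methylethyl and 1-aminocyclopropyl against each other. Among the three groups, only 1-aminocyclopentyl gives a number rather than a limit of the assay, and the other two stay together at that limit: the limit of > 0.5 h in this assay, at which 2 of the 3 values shown sit.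

On these data alone, with three groups, it remains open whether the half-life follows ring size in steps or falls sharply at the five-membered ring, which 1-aminocyclobutyl and 1-aminocyclohexyl on the same carbonyl carbon would help to separate. As far as these compounds go, the role of the amine within 1-aminocyclopentyl is also open, and a plain cyclopentyl or a 1-hydroxycyclopentyl group would show whether the lower number in this assay stays when the amine is gone.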